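The source may hold more compounds than are shown below. What is called first, only, known or untested is meant among the compounds shown, and "the series" means these compounds.

Measured in a functional assay on MCF7 cells (Homo sapiens) for antiproliferative activity, read by MTT assay, with a stated time of 72 h; on this read-out lower numbers stand for stronger inhibition and higher numbers for weaker inhibition:
Compound 1 `CCCSc1nc(N/N=C(\C)c2ccc(O)cc2)c2nnn(Cc3ccccc3)c2n1`: 21600 nM
Compound 2 `CCCSc1nc(N/N=C/c2ccc(Cl)cc2)c2nnn(Cc3ccccc3)c2n1`: > 64000 nM
Compound 3 `CCCSc1nc(N/N=C(\C)c2ccccc2O)c2nnn(Cc3ccccc3)c2n1`: 11000 nM

Compound 2 has only a limit of the assay, > 64000 nM, and no number. It stands higher than compound 1 and compound 3, beyond the scatter in both cases. Compound 4 `CCCSc1nc(N/N=C/c2ccc(N(C)C)cc2)c2nnn(Cc3ccccc3)c2n1` differs from compound 2 in one group: dimethylamino in place of chloro on an aromatic carbon. In words, dimethylamino stands in place of chloro on an aromatic carbon. The nearest guides are an at least 2.9-fold higher number from compound 1 to compound 2 (0.47 log units; beyond the scatter) and an at least 5.8-fold lower number from compound 2 to compound 3 (0.76 log units; beyond the scatter), though each swaps the whole group on the nitrogen, not the chloro alone. With those steps as a loose guide, a modest step to a lower number is expected in this assay: an at least 2.1-fold lower number from compound 2 to compound 4 (0.32 log units; beyond the scatter). For compound 4 the estimated value is 30000 nM, with an expected range of 10000 nM to 90000 nM.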

Compound 4, half-maximal inhibitory concentration: 12200 nM
Estimate against measurement, compound 4: 2.5-fold (0.39 log units) above; the measured number falls inside the stated range.
By their numbers in this assay, from the lowest: compounds 3, 4 and 1 (each within the scatter of the next). At a limit, above all of these: compound 2.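

Earlier steps swapped the whole group on the nitrogen, whereas here only the group on the aromatic carbon, para to a large group, changes. In this assay, 4-(dimethylamino)phenyl in place of 4-chlorophenyl alone gives an at least 5.2-fold lower number from compound 2 to compound 4 (0.71 log units; beyond the scatter), so this position can move the number beyond the scatter without a hydroxyl group on the ring. The step is only a bound, since compound 2 has a limit and no number: the limit of > 64000 nM in this assay, at which 1 of the 4 values shown sits.

On these data alone, whether a primary amine, a methoxy group or a carboxylic acid on this carbon would give a lower number stays open. So does whether dimethylamino would give a similar step with a methyl group on the carbon with a double bond to nitrogen.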